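The source may hold more compounds than are shown below. What is called first, only, known or untested is meant among the compounds shown, and "the series" means these compounds.

Working notes on the series. In a functional assay on HUVEC cells (Homo sapiens) for antiproliferative activity, read by MTT assay, with a stated time of 48 h (a higher number here means a weaker inhibitor, a lower number a stronger inhibitor), compound 1 `Cc1ccc(/C=C/c2nnc(-c3ccc4c(c3)OCCO4)o2)cc1` gives 45200 nM and compound 2 `O=[N+]([O-])c1ccc(/C=C/c2nnc(-c3ccc4c(c3)OCCO4)o2)cc1` gives 32100 nM, so these two values lie within the scatter of each other and compound 1 stands apart from neither. The unmeasured compound 3 `Clc1ccccc1/C=C/c1nnc(-c2ccc3c(c2)OCCO3)o1` differs from compound 1 by this change: 2-chlorophenyl in place of 4-methylphenyl on a double-bonded chain carbon bound to a double-bonded chain carbon. In words, 2-chlorophenyl comes in place of 4-methylphenyl on a double-bonded chain carbon bound to a double-bonded chain carbon. Going by the values given here, only one measured step bears on it, a 1.4-fold lower number from compound 1 to compound 2 (0.15 log units; within the scatter), for nitro in place of methyl on an aromatic carbon. Among the compounds with values here, that is a different exchange, and no measured compound carries 2-chlorophenyl. No step beyond the scatter is therefore expected in this assay, and the data suggest no direction. The expected step is a 1.2-fold lower number from compound 1 to compound 3 (0.08 log units; within the scatter). For compound 3 the estimated value is 38000 nM, with an expected range of 15000 nM to 90000 nM.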

Compound 3, half-maximal inhibitory concentration: 7710 nM
Estimate against measurement, compound 3: 4.9-fold (0.69 log units) above, outside the stated range (below it).
By their numbers in this assay, from the lowest: compound 3; then compounds 2 and 1 (each within the scatter of the next).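

In this assay, 2-chlorophenyl in place of 4-methylphenyl on a double-bonded chain carbon bound to a double-bonded chain carbon gives a 5.9-fold lower number from compound 1 to compound 3 (0.77 log units; beyond the scatter), so an exchange at this place can move the number beyond the scatter, which the step to compound 2 did not show. Heavy-atom, donor and acceptor counts are the same for the two groups, so these counts do not distinguish them. Nothing available bears on why the number moves.

The compounds shown leave open whether the chlorine or its placement carries the step, since 2-chlorophenyl differs from 4-methylphenyl in both, and 4-chlorophenyl and 2-methylphenyl would separate the two. Also open, from the compounds shown here alone, is how an amine or a carboxylic acid on that ring would read in this assay.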